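Phenyl in place of cyclopropyl on a weak binder

A few compounds are considered here, and "the series" means these few. Any claim that something is new, unique, unknown or untested is made for them only; others in the source may bear on it.

compound 1 `CCCN(CC1CC1)c1nc(C)nc(Nc2c(CC)cccc2CC)n1` — an assay on isolated protein for binding affinity to corticotropin-releasing factor receptor 1 (Homo sapiens); a lower number here means a stronger inhibitor, a higher number a weaker inhibitor: > 10000 nM
compound 2 `CCCN(Cc1ccccc1)c1nc(C)nc(Nc2ccc(C)cc2)n1` — this assay: > 10000 nM

The value of compound 1 is a limit of the assay, not a number. The value of compound 2 is a limit as well. Both sit at the limit of > 10000 nM in this assay, at which 2 of the 2 values shown sit, so no step beyond the scatter can be read from them. Compound 3 `CCCN(Cc1ccccc1)c1nc(C)nc(Nc2c(CC)cccc2CC)n1` differs from compound 1 by phenyl in place of cyclopropyl on a saturated chain carbon bound to a nitrogen on an aromatic ring. With compound 1 at a limit, the step from compound 1 to compound 3 is expected to be none beyond the scatter, as a number no higher from compound 1 to compound 3 (the limit leaves the size open). Compound 3 is therefore estimated at 10000 nM, within 3000 nM to 30000 nM.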

Compound 3, inhibition constant: > 10000 nM
Compound 3: only a limit was reported; the forecaster's own chance of this, stated with the estimate: 70%; the middle value sits exactly at the limit.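

No step can be read from compound 1 to compound 3, since both values are limits of the assay: the limit of > 10000 nM in this assay, at which 3 of the 3 values shown sit.

Going by these compounds, how strongly either compound binds, and so what phenyl in place of cyclopropyl changes, stays open.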